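The source may hold more compounds than are shown below. What is called first, only, known or untested is meant among the compounds shown, and "the series" means these compounds.

Measured compounds in an assay on HEK293 cells for displacement of a labelled ligand from Orexin receptor type 2 (Homo sapiens), read by scintillation counting, with a stated time of 90 min; a lower number here means a stronger inhibitor, a higher number a weaker inhibitor:
compound 1 `COc1ccc(N2C(=O)N(Cc3ccccc3F)c3ccccc3S2(=O)=O)cc1OC`: 6.31 nM
compound 2 `COc1cc(F)c(CN2C(=O)N(c3cnc(OC)c(OC)c3)S(=O)(=O)c3ccccc32)c(F)c1`: 0.398 nM
compound 3 `COc1cc(F)c(CN2C(=O)N(c3ccc(OC)c(OC)n3)S(=O)(=O)c3ccccc32)c(F)c1`: 0.2 nM

In this assay compound 1 stands highest of the three numbers; compound 2 and compound 3 both lie beyond the scatter below it. Compound 4 `COc1ccc(N2C(=O)N(Cc3ccccc3)c3ccccc3S2(=O)=O)cc1OC` differs from compound 1 by hydrogen in place of fluoro on an aromatic carbon. Within the data shown here, the one measured step, a 2.0-fold lower number from compound 2 to compound 3 (0.30 log units; within the scatter), concerns the dimethoxypyridinyl on the amide-type nitrogen and is within the scatter; it does not touch the benzyl side, so no measured pair bears on this change. With nothing to go on beyond compound 1 itself, the number for compound 4 is expected to stay close to it, a modest move to a higher number being as likely as none. The estimate for compound 4 is 10 nM, range 3 nM to 40 nM. This expected change is a 1.6-fold higher number from compound 1 to compound 4 (0.20 log units; within the scatter).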

Compound 4, inhibition constant: 79.4 nM
Beside the measured number, compound 4's estimate is 7.9-fold (0.90 log units) below it; the measured number lies above the stated range.
By their numbers in this assay, from the lowest: compounds 3 and 2 (each within the scatter of the next); then compound 1; then compound 4.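

In this assay, 2-fluorobenzyl to benzyl gives a 13-fold higher number from compound 1 to compound 4 (1.10 log units; beyond the scatter), so the fluoro on this aromatic carbon, ortho to a large group, matters on its own, although it is a single heavy atom. The earlier step touched only the dimethoxypyridinyl, whereas this one shows that the benzyl side responds beyond the scatter. No measurement at hand explains the size of this step.

Going by these compounds, whether chloro, methyl or nitrile at this position would keep the number of compound 1 remains open. Also open, on these data alone, is whether hydrogen in place of fluoro costs as much in the dimethoxypyridinyl compounds.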